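Series notes: butyl in place of (tert-butoxycarbonyl)amino

This account rests on a few compounds, and the source may have more. Where it says the series, first, only, none or still open, it means among the compounds named here.

Measured so far in a functional assay on cells (Splenocyte, Mus musculus, strain BALB/c) for inhibition, read by scintillation counting and thymidine incorporation, with stated times of 48 h and 8 h; a higher number here means a weaker inhibitor, a lower number a stronger inhibitor:
compound 1, `COc1cccc(-c2nc(Cc3c[nH]c4ccccc34)no2)c1`: 11100 nM
compound 2, `CCCCc1nc(Cc2c[nH]c3ccccc23)no1`: > 50000 nM
compound 3, `COc1cc(-c2noc(-c3ccc(NC(=O)OC(C)(C)C)cc3)n2)cc(OC)c1OC`: 2200 nM

The value of compound 2 in this assay is a limit of the assay, not a number (the limit of > 50000 nM in this assay, at which 1 of the 3 values shown sits). Among the two numbers given, compound 3 stands lowest; the nearest is compound 1, whose number is higher by a margin beyond the usual scatter.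

The next step starts from compound 3 and leads to compound 4, `CCCCc1ccc(-c2nc(-c3cc(OC)c(OC)c(OC)c3)no2)cc1`. The change is butyl in place of (tert-butoxycarbonyl)amino on an aromatic carbon, on an aromatic carbon of a six-membered aromatic ring of carbon only, para to a large group. Going by the values given here, no step between two measured compounds of this kind is available, so the expected step in this assay from compound 3 to compound 4 rests on the structural change alone; a step of moderate size toward a weaker inhibitor is expected, a 2.0-fold higher number from compound 3 to compound 4 (0.31 log units; beyond the scatter). For compound 4 the estimate in this assay is 4500 nM, with a range from 1200 nM to 18000 nM.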

Compound 4, half-maximal inhibitory concentration: 36200 nM
Estimate against measurement, compound 4: 8.0-fold (0.91 log units) below; the measured number lies above the stated range.
By their numbers in this assay, from the lowest: compound 3; then compound 1; then compound 4. At a limit, above all of these: compound 2.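

In this assay, the aromatic carbon para to a large group proves sensitive to the group it carries: the exchange of (tert-butoxycarbonyl)amino for butyl gives a 16-fold higher number from compound 3 to compound 4 (1.22 log units; beyond the scatter), a large loss of inhibition. This single change removes a carbonyl, the hydrogen-bond donor and the hydrogen-bond acceptors together with part of the heavy-atom count, and the step alone cannot separate these differences. No measurement shown bears on the cause of this step.

The compounds shown leave open whether a free amine or a simple acetamide at this position restores the number of compound 3, which would show whether the nitrogen alone is enough. On these data alone, a chain longer than butyl, or a carboxylic acid, at the same carbon also remains open.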